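The compounds below may be only part of what the source reports. "The series", "measured", "known", "first", "only" and "open" are said of these compounds alone.

In a functional assay on EOL1 cells (Homo sapiens) for inhibition, read by fluorescence, with a stated time of 72 h; on this read-out lower numbers stand for stronger inhibition of growth and higher numbers for weaker inhibition of growth:

- compound 1 `CCCCn1cnc2c(NCc3cccc(Cl)c3)nc(N[C@H]3CC[C@H](N)CC3)nc21`: 350 nM
- compound 2 `CC(C)CCn1cnc2c(NCc3cccc(Cl)c3)nc(N[C@H]3CC[C@H](N)CC3)nc21`: 1330 nM
- compound 3 `CC(C)CCn1cnc2c(Nc3ccccc3)nc(N[C@H]3CC[C@H](N)CC3)nc21`: 10 nM

Among these three numbers, compound 1 at 350 nM is the second highest, lying below compound 2 and above compound 3. The unmeasured compound 4 `CCCCn1cnc2c(Nc3cccc(Cl)c3)nc(N[C@H]3CC[C@H](N)CC3)nc21` keeps the chain and the shared core of compound 1 and changes one group: 3-chlorophenyl in place of 3-chlorobenzyl on a nitrogen on an aromatic ring. In words, this is 3-chlorophenyl in place of 3-chlorobenzyl on a nitrogen on an aromatic ring.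

Going by the values given here, the closest precedent is a 130-fold lower number from compound 2 to compound 3 (2.12 log units; beyond the scatter), a large step in which phenyl replaced 3-chlorobenzyl at that same nitrogen. Among the compounds with values here, it is not an exact match, since the chlorine left in that step and stays in compound 4, and no measured pair shows what the chlorine does alone. That step was also measured on a different chain. Changing the chain gave a 3.8-fold higher number from compound 1 to compound 2 (0.58 log units; beyond the scatter), a modest step, so the chain may alter how far the swap carries over.

A large step towards a lower number in this assay is therefore expected, though perhaps somewhat smaller than the precedent. The expected change is a 70-fold lower number from compound 1 to compound 4 (1.85 log units; beyond the scatter). For compound 4 the estimated value is 5 nM, with an expected range of 1.5 nM to 25 nM.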

Compound 4, concentration for 50% growth inhibition: 160 nM
For compound 4 the middle estimate is 32-fold (1.51 log units) below the measured one, outside the stated range (above it).
By their numbers in this assay, from the lowest: compound 3; then compound 4; then compound 1; then compound 2.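

In this assay, putting 3-chlorophenyl in place of 3-chlorobenzyl on this nitrogen still moves the result the same way, with a 2.2-fold lower number from compound 1 to compound 4 (0.34 log units; beyond the scatter), but the gain is modest. Set against the earlier 130-fold lower number from compound 2 to compound 3 (2.12 log units; beyond the scatter), this shows that the large drop does not follow simply from going from a benzyl to a phenyl group on this nitrogen: what the swap delivers depends on what else the molecule carries, here the chlorine, the chain or both. No measurement on hand explains why the two steps differ so much in size.

The two steps differ in two places at once, the chlorine on the ring and the chain on the shared core, so the compounds shown cannot say which of these matters, and the unsubstituted phenyl group on the butyl chain or the 3-chlorophenyl group on the 3-methylbutyl chain would be needed to pull them apart. Also open, as far as these compounds go, is whether another group in place of the chlorine, such as a fluorine or a methoxy group, or a longer chain such as hexyl, would keep or lose the gain.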